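Series notes: bicyclic urea aryl on the amide nitrogen

The source may hold more compounds than are shown below. What is called first, only, known or untested is meant among the compounds shown, and "the series" means these compounds.

Going by the values given here, compound 3 `CN(C)C1(Cc2ccccc2)CCN(c2cc(C(F)(F)F)ccc2CNC(=O)Nc2ccc3cccnc3c2)CC1` stands highest of the three measured members in an assay on CHO cells for displacement of a labelled ligand from transient receptor potential cation channel subfamily V member 1 (Homo sapiens), read by scintillation counting, with a stated time of 60 min (on this read-out higher numbers stand for weaker inhibition and lower numbers for stronger inhibition), giving 14.1 nM. Compound 1 `CN(C)C1(Cc2ccccc2)CCN(c2cc(C(F)(F)F)ccc2CNC(=O)Nc2cccc3c2CC(O)CC3)CC1` gives 0.95 nM, and compound 2 `CN(C)C1(Cc2ccccc2)CCN(c2cc(C(F)(F)F)ccc2CNC(=O)Nc2cccc3[nH]c(=O)ccc23)CC1` gives 1.67 nM; the step of a 1.8-fold higher number from compound 1 to compound 2 (0.24 log units; within the scatter) is small, so these two are not ordered against each other. Against both, compound 3 is clearly weaker: a 15-fold higher number from compound 1 to compound 3 (1.17 log units; beyond the scatter) and an 8.4-fold higher number from compound 2 to compound 3 (0.93 log units; beyond the scatter).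

Compound 4 `CN(C)C1(Cc2ccccc2)CCN(c2cc(C(F)(F)F)ccc2CNC(=O)Nc2cccc3cnccc23)CC1` is the next member, differing from compound 3 by isoquinolin-5-yl in place of quinolin-7-yl on an amide-type nitrogen: the same atoms, joined differently. Among the compounds with values here, no measured step covers this particular exchange. Within the data shown here, the two steps that bear on it, a 15-fold higher number from compound 1 to compound 3 (1.17 log units; beyond the scatter) and an 8.4-fold higher number from compound 2 to compound 3 (0.93 log units; beyond the scatter), show only that the bicyclic aryl group on the amide nitrogen moves this assay by large to modest amounts, and that compound 3 carries the weakest of the three variants seen. A rearranged group at the same site is therefore expected to move the number beyond the scatter, and since compound 3 is the weakest reference, the more likely direction is downward, toward the range of compounds 1 and 2. The expected step is a 2.8-fold lower number from compound 3 to compound 4 (0.45 log units; beyond the scatter), a modest improvement. Compound 4 is estimated at 5 nM in this assay, with a range from 1.2 nM to 25 nM.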

Compound 4, inhibition constant: 0.67 nM
The estimate for compound 4 lay 7.5-fold (0.87 log units) above the measured number, outside the stated range (below it).
By their numbers in this assay, from the lowest: compounds 4, 1 and 2 (each within the scatter of the next, the first and the last beyond it); then compound 3.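

Working notes: in this assay, isoquinolin-5-yl in place of quinolin-7-yl on the amide-type nitrogen gives a 21-fold lower number from compound 3 to compound 4 (1.32 log units; beyond the scatter), so with the same atoms and the same counts of donors and acceptors, the way the bicyclic group is joined is enough to produce a large step at this position. The earlier compounds shown here left open whether a low number here goes with an oxygen-bearing group, since the hydroxyl of compound 1 and the carbonyl of compound 2 stood against the oxygen-free compound 3, but compound 4 goes against that pattern: it carries no oxygen in this group, yet a 1.4-fold lower number from compound 1 to compound 4 (0.15 log units; within the scatter) and a 2.5-fold lower number from compound 2 to compound 4 (0.40 log units; beyond the scatter). Nothing on hand explains why the two joinings differ so much.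

The exchange alters both the place of the ring nitrogen and the point of attachment, and the compounds shown do not separate the two; quinolin-5-yl would hold the attachment point of compound 4 while moving the ring nitrogen. From the compounds shown here alone, whether the ring nitrogen matters at all stays open too, a question that naphthalen-1-yl, with carbon in its place, would address.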